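The source may report more compounds than this note shows. Statements on the series, on what has been measured and on what is new or still open speak of the compounds shown alone.

Measured in a functional assay on MCF7 cells (Homo sapiens) for antiproliferative activity; a lower number here means a stronger inhibitor, a higher number a weaker inhibitor:
- compound 1 `CCNCCCOc1ccc2cc(NC(=O)c3ccc(O)c(CC=C(C)C)c3)c(=O)oc2c1C`: 980 nM
- compound 2 `CC(C)=CCc1cc(C(=O)Nc2cc3ccc(OCCCN(C)C(C)C)c(C)c3oc2=O)ccc1O`: 1050 nM

Compound 2, at 1050 nM, stands within the scatter of compound 1, at 980 nM. Compound 3 `CC(C)=CCc1cc(C(=O)Nc2cc3ccc(OCCCN(C(C)C)C(C)C)c(C)c3oc2=O)ccc1O` has isopropyl in place of methyl on an amine nitrogen, which turns isopropyl(methyl)amino into diisopropylamino. Among the measured compounds shown here, one measured step bears on this, as it also changes the groups on that amine nitrogen: a 1.1-fold higher number from compound 1 to compound 2 (0.03 log units; within the scatter). For the measured compounds named here, that step is small, and it is the only guide, since no measured compound carries the diisopropylamino group. In this assay, therefore, no change beyond the scatter is expected, and no direction can be called with confidence. The expected step is a 1.0-fold higher number from compound 2 to compound 3 (0.02 log units; within the scatter). For compound 3 the estimated value is 1100 nM, with an expected range of 600 nM to 2000 nM.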

Compound 3, half-maximal inhibitory concentration: 1310 nM
Compound 3: the middle estimate sits 1.2-fold (0.08 log units) below what was measured; low and high end bracket the measured number.
By their numbers in this assay, from the lowest: compounds 1, 2 and 3 (each within the scatter of the next).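

In this assay, isopropyl in place of methyl on the amine nitrogen gives a 1.2-fold higher number from compound 2 to compound 3 (0.10 log units; within the scatter), so adding this second isopropyl group leaves the result within the scatter. Read across the full change from ethylamino to diisopropylamino, the compounds show a 1.3-fold higher number from compound 1 to compound 3 (0.13 log units; within the scatter), which means that the three substituted amines shown here cannot be told apart in this assay, even at the ends of the series. Nothing available accounts for this lack of a measurable difference.

The compounds shown leave open whether a primary amine, a piperidine, a morpholine or a carboxylic acid at this end of the chain would move the number beyond the scatter. They also leave open whether a longer chain between the oxygen on the aromatic ring and the amine nitrogen would do so.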